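This account rests on a few compounds, and the source may have more. Where it says the series, first, only, none or still open, it means among the compounds named here.

Working notes on the hydroxamic chain series. In a functional assay on CNE-2 cells (Homo sapiens) for inhibition, read by MTT assay, with a stated time of 72 h (a higher number here means a weaker inhibitor, a lower number a stronger inhibitor), compound 1 `Nc1ncnc2c1c(-c1cnc3[nH]ccc3c1)nn2CC(=O)NO` gives > 150000 nM, which is a limit and not a number. Compound 2 `Nc1ncnc2c1c(-c1cnc3[nH]ccc3c1)nn2CCCCC(=O)NO` gives > 150000 nM, again a limit. Among the measured compounds shown here, compound 3 `Nc1ncnc2c1c(-c1cnc3[nH]ccc3c1)nn2CCCCCCC(=O)NO` gives 19500 nM, the only actual number so far.

Compound 4 `Nc1ncnc2c1c(-c1cnc3[nH]ccc3c1)nn2CCC(=O)NO` departs from compound 3 by hydroxycarbamoyl in place of 4-(hydroxycarbamoyl)butyl on a saturated chain carbon, two bonds along the chain from an aromatic nitrogen.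

For the measured compounds named here, two measured steps bear on this shortening, read in reverse: an at least 7.6-fold lower number from compound 1 to compound 3 (0.88 log units; beyond the scatter), and an at least 7.6-fold lower number from compound 2 to compound 3 (0.88 log units; beyond the scatter). Both sizes are bounded by a limit, so the true gaps may be larger. Going by the values given here, both compounds with chains shorter than that of compound 3 sit at the limit, and no shortened compound goes against this. A step of modest size or more towards a higher number in this assay is therefore expected, and a reported limit is the likely outcome.

The expected change is a 9.2-fold higher number from compound 3 to compound 4 (0.97 log units; beyond the scatter). Compound 4 is estimated at 180000 nM, with an expected range of 70000 nM to 400000 nM.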

Compound 4, half-maximal inhibitory concentration: > 150000 nM
Compound 4: a limit, no number; the forecaster's own chance of this, stated with the estimate: 85%; the middle value is on the limit's open side.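

In this assay compound 4 gives > 150000 nM, which is a limit and not a number. Hydroxycarbamoyl in place of 4-(hydroxycarbamoyl)butyl, on a saturated chain carbon, two bonds along the chain from an aromatic nitrogen, gives an at least 7.6-fold higher number from compound 3 to compound 4 (0.88 log units; beyond the scatter), so a third chain shorter than that of compound 3 also gives no number, and no compound shown goes against this. The steps among compound 1, compound 2 and compound 4 cannot be read, with all three at the same limit: the limit of > 150000 nM in this assay, at which 3 of the 4 values shown sit.

From the compounds shown here alone, whether a longer chain than that of compound 3 would lower the number further remains open. Also open, going by these compounds, is whether a carboxylic acid or a primary amide in place of the hydroxycarbamoyl end would keep the value of compound 3 at this chain length.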